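A Pyridyl Ether in Place of a Cyclopropylmethyl Ether

The compounds below may be only part of what the source reports. "The series", "measured", "known", "first", "only" and "open" are said of these compounds alone.

Compound 2 `CC(C)CCn1ccc(-c2ccc(OCC3CC3)cc2)c(C#N)c1=O` gives 290 nM in a functional assay on CHO cells for positive allosteric modulation of metabotropic glutamate receptor 2 (Homo sapiens), read by scintillation counting and GTPgammaS binding, with a stated time of 30 min (a higher number here means that more compound is needed for the effect, a lower number that less compound is needed), the highest of the two numbers shown. Compound 1 `COc1ccccc1-c1ccn(CCC(C)C)c(=O)c1C#N` reaches only a limit in this assay, > 10000 nM (the limit of > 10000 nM in this assay, at which 1 of the 3 values shown sits). Within the data shown here, compound 3 `CC(C)CCn1ccc(-c2ccc(OCC3CC3)c(Cl)c2)c(C#N)c1=O` gives 110 nM in this assay, and the single measured step, a 2.6-fold lower number from compound 2 to compound 3 (0.42 log units; beyond the scatter), concerns a chloro entering on an aromatic carbon of the shared core.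

Compound 4 `Cc1cc(Oc2ccc(-c3ccn(CCC(C)C)c(=O)c3C#N)cc2)ccn1` differs from compound 2 at a different place: 2-methylpyridin-4-yl in place of cyclopropylmethyl on an oxygen on an aromatic ring. Among the measured compounds shown here, no measured pair alters the group on that oxygen, so the step from compound 2 to compound 4 has no direct precedent among the measured compounds; the chloro step lies elsewhere on the core and gives no guide to size or direction here. The expectation therefore rests on compound 2 alone and is wide. The estimated change, a 1.0-fold higher number from compound 2 to compound 4 (0.01 log units; within the scatter), is not expected to exceed the usual scatter. Compound 4 is estimated at 300 nM, within a range from 80 nM to 1500 nM.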

Compound 4, half-maximal effective concentration: 447 nM
The estimate for compound 4 lay 1.5-fold (0.17 log units) below the measured number; low and high end bracket the measured number.
By their numbers in this assay, from the lowest: compound 3; then compounds 2 and 4 (each within the scatter of the next). At a limit, above all of these: compound 1.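

With 2-methylpyridin-4-yl in place of cyclopropylmethyl, the oxygen on the aromatic ring now has a measured change in this assay: a 1.5-fold higher number from compound 2 to compound 4 (0.19 log units; within the scatter). A six-membered aromatic ring with one nitrogen thus stands in for a three-membered ring of carbon only, and seven heavy atoms for four, with no difference beyond the scatter, so in this one pair that oxygen accepts an aromatic group as well as cyclopropylmethyl. Nothing measured among these compounds explains why the two groups give numbers so close together.

On these data alone, what a plain phenyl or a pyridin-4-yl without the methyl would give on that oxygen remains open. So does whether the chloro of compound 3 would carry over to compound 4 with a step of similar size.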